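A triazolyl group replaces 2-(pyrrolidin-1-yl)ethyl

This account rests on a few compounds, and the source may have more. Where it says the series, first, only, none or still open, it means among the compounds named here.

Compound 1 `C=C1C(=O)O[C@H]2[C@H]1CC/C(COC(=O)N1CCC(F)(F)CC1)=C\CC[C@@]1(C)O[C@@H]21`: 460 nM
Compound 2 `C=C1C(=O)O[C@H]2[C@H]1CC/C(COC(=O)NCCN1CCCC1)=C\CC[C@@]1(C)O[C@@H]21`: 6560 nM

In a functional assay on MDA-MB-435 cells (Homo sapiens) for inhibition (a lower number here means a stronger inhibitor of growth, a higher number a weaker inhibitor of growth), compound 2 stands highest of the two at 6560 nM. Going by the values given here, the only measured step is large: a 14-fold higher number from compound 1 to compound 2 (1.15 log units; beyond the scatter). Compound 3 `C=C1C(=O)O[C@H]2[C@H]1CC/C(COC(=O)Nc1n[nH]c(SC)n1)=C\CC[C@@]1(C)O[C@@H]21` carries 5-(methylsulfanyl)-1H-1,2,4-triazol-3-yl in place of 2-(pyrrolidin-1-yl)ethyl on an amide-type nitrogen. The measured step concerns this same side chain, but no triazolyl group has been measured, so it guides the expectation only loosely. A moderate move to a lower number is expected, towards compound 1 at 460 nM. The estimated step is a 4.4-fold lower number from compound 2 to compound 3 (0.64 log units; beyond the scatter). For compound 3 the expected value is 1500 nM, with an estimated range from 400 nM to 5000 nM.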

Compound 3, concentration for 50% growth inhibition: 2240 nM
Estimate against measurement, compound 3: 1.5-fold (0.17 log units) below, within the range that was stated.
By their numbers in this assay, from the lowest: compound 1; then compound 3; then compound 2.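

In this assay the amide-type nitrogen accepts a five-membered aromatic ring: 5-(methylsulfanyl)-1H-1,2,4-triazol-3-yl in place of 2-(pyrrolidin-1-yl)ethyl, with the same count of heavy atoms, gives a modest gain (a 2.9-fold lower number from compound 2 to compound 3 (0.47 log units; beyond the scatter)). That gain stops short of the 4,4-difluoropiperidin-1-yl group on the carbonyl carbon (a 4.9-fold higher number from compound 1 to compound 3 (0.69 log units; beyond the scatter)). No measurement at hand accounts for either step. Going by these compounds, it remains open whether the methylsulfanyl group contributes to the gain, and whether a phenyl ring on this nitrogen would come closer to compound 1.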